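Series notes: from compound 3 toward compound 4

A few compounds are considered here, and "the series" means these few. Any claim that something is new, unique, unknown or untested is made for them only; others in the source may bear on it.

Measured so far in a functional assay on HL-60 cells (Homo sapiens) for antiproliferative activity, read by MTT assay, with a stated time of 48 h; a higher number here means a weaker inhibitor, a lower number a stronger inhibitor:
compound 1 `COC/C1=C/C[C@](C)(CCC=C(C)C)/C=C/[C@@H](OC(=O)C=C(C)C)[C@](C)(OC)/C=C/C1=O` — 4050 nM
compound 2 `CO[C@]1(C)/C=C/C(=O)/C(CO)=C\C[C@](C)(CCC=C(C)C)/C=C/[C@H]1OC(=O)C=C(C)C` — 14300 nM
compound 3 `CC(C)=CCC[C@]1(C)/C=C/[C@@H](OC(=O)C=C(C)C)[C@](C)(O)/C=C/C(=O)/C(CCl)=C\C1` — 160 nM

Compound 3 gives the lowest number of the three in this assay; the nearest value, that of compound 1, lies well above it, and that of compound 2 further still, both gaps beyond the scatter. Within the data shown here, compounds 1 and 2 carry a methoxymethyl or hydroxymethyl group where compound 3 carries chloromethyl, but they also differ from compound 3 at the oxygen on the saturated carbon, so no single-place step to compound 3 is available.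

Compound 4 `CC(C)=CCC[C@]1(C)/C=C/[C@@H](OC(=O)C=C(C)C)[C@](C)(O)/C=C/C(=O)/C(C(=O)N(C(C)C)C(C)C)=C\C1` is the next candidate. Its difference from compound 3 is diisopropylcarbamoyl in place of chloromethyl on a double-bonded ring carbon.

Among the measured compounds shown here, the only measured single-place step, a 3.5-fold higher number from compound 1 to compound 2 (0.55 log units; beyond the scatter), concerns the oxygen on the saturated carbon, not the double-bonded ring carbon, so it does not bear directly on this change. What the data show is that the two compounds lacking the chloromethyl group, compounds 1 and 2, both sit far above compound 3 in this assay.

A step toward a weaker inhibitor is therefore expected, of a size comparable to the gap between compound 3 and compounds 1 and 2, estimated as a 19-fold higher number from compound 3 to compound 4 (1.27 log units; beyond the scatter). Compound 4 is thus estimated at 3000 nM, with a range of 500 nM to 15000 nM.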

Compound 4, half-maximal inhibitory concentration: 12700 nM
The estimate for compound 4 lay 4.2-fold (0.63 log units) below the measured number; the range from low to high includes it.
By their numbers in this assay, from the lowest: compound 3; then compound 1; then compounds 4 and 2 (each within the scatter of the next).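

Among these compounds, this is the first single-place change read at the double-bonded ring carbon. In this assay replacing chloromethyl with diisopropylcarbamoyl gives a 79-fold higher number from compound 3 to compound 4 (1.90 log units; beyond the scatter), a large step beyond the scatter, so what this carbon carries can strongly change the antiproliferative reading on the shared core. Among the compounds shown here, the only earlier single-place step, a 3.5-fold higher number from compound 1 to compound 2 (0.55 log units; beyond the scatter), lay at the oxygen on the saturated carbon and said nothing about this position. The change swaps a group of 2 heavy atoms for one of 9 heavy atoms and also brings in a carbonyl, so this single pair cannot separate the loss of chloromethyl from the arrival of the amide.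

Still open, going by these compounds, is how a smaller amide such as dimethylcarbamoyl, a primary carboxamide, a carboxylic acid, or bromomethyl at the same carbon would read, and whether chloromethyl stands out among such groups or diisopropylcarbamoyl alone carries the penalty. Nothing shown here accounts for the size of the step.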